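Hydroxyethyl Replaces the Ester on the Triazole Ring

The compounds below may be only part of what the source reports. "The series", "measured", "known", "first", "only" and "open" are said of these compounds alone.

Of the compounds shown here, three sharing one core have been measured in an ADME assay on SK-OV-3 cells (Homo sapiens) for cytotoxicity, read by sulforhodamine B assay, with a stated time of 48 h, tested at 10 uM; a lower number here means less inhibition, a higher number more inhibition at the concentration tested (going by the name of the read-out). Compound 1 `COc1nc2ccc(Br)cc2cc1C(c1ccccc1)n1cc(-c2ccc(Br)cc2)nn1` gives 13.4%. Compound 2 `CCCCCCCCc1cn(C(c2ccccc2)c2cc3cc(Br)ccc3nc2OC)nn1` gives 2.06%, and compound 3 `CCOC(=O)c1cn(C(c2ccccc2)c2cc3cc(Br)ccc3nc2OC)nn1` gives 2.01%. Compound 3 sits at the low end of this small set: its number lies within the scatter of compound 2, while against compound 1 it is clearly lower, as the step of a number 11.4 percentage points lower from compound 1 to compound 3 (beyond the scatter) shows. The two steps that start from compound 1, namely a number 11.3 percentage points lower from compound 1 to compound 2 (beyond the scatter) and a number 11.4 percentage points lower from compound 1 to compound 3 (beyond the scatter), are the only ones beyond the scatter; the step of a number 0.1 percentage points lower from compound 2 to compound 3 (within the scatter) changed nothing that can be told apart from noise.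

Compound 4 `COc1nc2ccc(Br)cc2cc1C(c1ccccc1)n1cc(CCO)nn1` has not yet been measured. Its structure differs from compound 3 in one place: 2-hydroxyethyl in place of ethoxycarbonyl on an aromatic carbon. Among the compounds with values here, no measured step swaps these two groups, so the closest guide is the step of a number 0.1 percentage points lower from compound 2 to compound 3 (within the scatter), where a large change on the same aromatic carbon left the number unmoved. The small groups on that carbon in compound 2 and compound 3 both gave low inhibition, and the expectation is therefore that compound 4 stays at a similar level, with an estimated step of a number 2 percentage points higher from compound 3 to compound 4 (within the scatter) in this assay. Compound 4 is thus estimated at 4%, within a range from -6% to 15%.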

Compound 4, a percentage reported as inhibition, at one concentration (the size of the read-out at that concentration, not a potency): 8.46%
Compound 4: the middle estimate sits 4.5 percentage points below what was measured, and the stated range covers the measured number.
By their numbers in this assay, from the lowest: compounds 3, 2, 4 and 1 (each within the scatter of the next, the first and the last beyond it).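

Replacing ethoxycarbonyl with 2-hydroxyethyl on this aromatic carbon of the five-membered ring swaps a group with no hydrogen-bond donor for one with a hydrogen-bond donor, and in this assay the result is a number 6.5 percentage points higher from compound 3 to compound 4 (within the scatter) and so cannot be told apart from noise; the comparison with the octyl group gives the same reading, with a number 6.4 percentage points higher from compound 2 to compound 4 (within the scatter) on this single measurement. Within the data shown here, the comparison with the 4-bromophenyl group gives a number 4.9 percentage points lower from compound 1 to compound 4 (within the scatter) so compound 4 cannot be separated from compound 1 either, even though compound 1 stands clearly apart from compound 2 and compound 3, which makes 2-hydroxyethyl the first group at this position that falls within the scatter of all the others. Nothing available here offers a reason for these numbers.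

Still open, going by these compounds, is whether the clear gap seen for compound 1 belongs to the 4-bromophenyl group as a whole or to its bromine, which a plain phenyl group at the same carbon would help to separate. On these data alone, it is also open whether a carboxylic acid or an amine at this position would leave the number within the same narrow band or move it beyond the scatter.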